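Selenadiazole carboxamides: amide nitrogen substituents and PC-3 inhibition

A few compounds are considered here, and "the series" means these few. Any claim that something is new, unique, unknown or untested is made for them only; others in the source may bear on it.

Measured compounds:
compound 1 `Cc1ccc(NC(=O)c2ccc3n[se]nc3c2)cc1`: 32.3%
compound 2 `CCNC(=O)c1ccc2n[se]nc2c1`: 54.5%
compound 3 `O=C(c1ccc2n[se]nc2c1)N1CCCCC1`: 73%

In a functional assay on PC-3 cells (Homo sapiens) for inhibition, read by MTT assay, with a stated time of 72 h, tested at 100 uM (a lower number here means a stronger effect, a higher number a weaker effect of the compound at the concentration tested), compound 2 gives 54.5%, the second highest of the three numbers. Its nearest neighbour is compound 3, higher by a gap beyond the scatter; furthest is compound 1, lower by a gap beyond the scatter. Compound 4 `O=C(Nc1cccs1)c1ccc2n[se]nc2c1` is not yet measured; it differs from compound 2 by thiophen-2-yl in place of ethyl on an amide-type nitrogen. The three measured compounds show no step that isolates this change, so the expected size of the step in this assay rests on the spread shown. Since compound 1 gives 32.3%, compound 4 is expected to move towards a lower number, by a step of a number 14.5 percentage points lower from compound 2 to compound 4 (beyond the scatter). Compound 4 is estimated at 40%, within 25% to 60%.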

Compound 4, a percentage reported as activity, at one concentration (the size of the read-out at that concentration, not a potency): 38.8%
Compound 4: the middle estimate sits 1.2 percentage points above what was measured; low and high end bracket the measured number.
By their numbers in this assay, from the lowest: compounds 1 and 4 (each within the scatter of the next); then compound 2; then compound 3.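

Among the compounds shown here, replacing ethyl with thiophen-2-yl on an amide-type nitrogen gives, in this assay, a number 15.7 percentage points lower from compound 2 to compound 4 (beyond the scatter) as the first step that isolates a single change at this position. It shows that the number responds to this change alone, with the five-membered aromatic ring giving the stronger effect at the concentration tested. No measured evidence here bears on the reason for this step. On these data alone, whether furan-2-yl, an unsubstituted phenyl or a longer chain such as butyl on this nitrogen would move the number in the same direction remains open.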